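This account rests on a few compounds, and the source may have more. Where it says the series, first, only, none or still open, it means among the compounds named here.

Measured so far in an assay on HEK293 cells for displacement of a labelled ligand from metabotropic glutamate receptor 5 (Homo sapiens), with a stated time of 2 h; on this read-out lower numbers stand for stronger inhibition and higher numbers for weaker inhibition:

compound 1 `CC(C)N1CCc2nc(C#Cc3cccnc3)ccc2C1=O`: 19600 nM
compound 2 `O=C1c2ccc(C#Cc3ccccc3)nc2CCN1C1CCCC1`: 890 nM
compound 3 `O=C1c2ccc(C#Cc3cccc(Cl)c3)nc2CCN1C1CCCC1`: 5230 nM

Compound 3 stands second highest of the three numbers in this assay: nearest to it is compound 1, furthest from it is compound 2. Within the data shown here, the one measured step that touches compound 3 is a 5.9-fold higher number from compound 2 to compound 3 (0.77 log units; beyond the scatter), a chloro in place of hydrogen on an aromatic carbon.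

Compound 4 `O=C1c2ccc(C#Cc3cccnc3)nc2CCN1C1CCCC1` differs from compound 3 by pyridin-3-yl in place of 3-chlorophenyl on a triple-bonded carbon. Among the measured compounds shown here, no measured pair covers this exchange directly. Two things bear on it indirectly: the step of a 5.9-fold higher number from compound 2 to compound 3 (0.77 log units; beyond the scatter) shows that the chloro is what separates compound 3 from the phenyl analogue, and compound 1, which carries the same pyridin-3-yl but a different group on the amide nitrogen, gives 19600 nM, so that pair cannot be read as a step. Removing the chloro alone would suggest a move back toward compound 2, while compound 1 argues against a large gain. For compound 4 a step of a 2.1-fold lower number from compound 3 to compound 4 (0.32 log units; beyond the scatter) is expected, toward a lower number, with wide uncertainty. The estimate for compound 4 in this assay is 2500 nM, in the range 600 nM to 10000 nM.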

Compound 4, inhibition constant: > 32000 nM
Compound 4: no number, only a limit; the forecaster's own chance of this, stated with the estimate: 5%; at least 12-fold (1.10 log units) between middle value and limit.
By their numbers in this assay, from the lowest: compound 2; then compound 3; then compound 1. At a limit, above all of these: compound 4.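

In this assay compound 4 gives > 32000 nM, which is a limit of the assay and not a number. On the triple-bonded carbon, pyridin-3-yl in place of 3-chlorophenyl brings no return toward the phenyl analogue: the exchange is an at least 6.1-fold higher number from compound 3 to compound 4 (0.78 log units; beyond the scatter). Pyridin-3-yl in place of phenyl on the triple-bonded carbon is an at least 35-fold higher number from compound 2 to compound 4 (1.55 log units; beyond the scatter). With cyclopentyl on the amide-type nitrogen, both departures from plain phenyl shown here, the 3-chlorophenyl of compound 3 and the pyridin-3-yl of compound 4, raise the number, leaving compound 2 lowest of the three.

Cyclopentyl in place of isopropyl on an amide-type nitrogen in a ring is an at least 1.6-fold higher number from compound 1 to compound 4 (0.21 log units; that floor lies within the scatter); this step cannot be read, so cyclopentyl against isopropyl stays undecided for pyridin-3-yl. Open too, going by these compounds, is whether a phenyl carrying fluoro or methoxy, or pyridin-2-yl on the triple-bonded carbon, would stay close to compound 2.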